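This account rests on a few compounds, and the source may have more. Where it says the series, first, only, none or still open, it means among the compounds named here.

The series shares the core of compound 1 `CS(=O)(=O)c1ccc(-c2cnc3[nH]cc(-c4nnc(-c5ccc(F)cc5)o4)c(=O)c3c2)cc1`, which carries a 4-fluorophenyl. In a functional assay on MCF7 cells (Homo sapiens) for inhibition, read by MTT assay, with a stated time of 24 h, tested at 5 uM (a lower number here means less inhibition of growth, a higher number more inhibition of growth at the concentration tested), compound 1 gives 3.78%. Among the measured compounds shown here, compound 2 `Cc1ccc(-c2nnc(-c3c[nH]c4ncc(-c5ccc(S(C)(=O)=O)cc5)cc4c3=O)o2)cc1` gives 6.26% in this assay, and the only single-point step measured so far, a number 2.5 percentage points higher from compound 1 to compound 2 (within the scatter), is methyl in place of fluoro on an aromatic carbon. For the measured compounds named here, compound 3 `O=c1c(-c2nnc(-c3ccc(Cl)cc3)o2)c[nH]c2ncc(-c3ccccc3)cc12` gives 12% in this assay; no single-point step links it to compound 1, and the gap between the two numbers lies within the scatter. Compound 1 thus sits at the lower end of the three numbers shown, with neither gap exceeding the scatter.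

Compound 4 `Cc1cccc(-c2nnc(-c3c[nH]c4ncc(-c5ccc(S(C)(=O)=O)cc5)cc4c3=O)o2)c1` is the next compound to be measured. Relative to compound 1 the change is 3-methylphenyl in place of 4-fluorophenyl on an aromatic carbon. Going by the values given here, the one measured step that bears on it is the exchange of methyl for fluoro, a number 2.5 percentage points higher from compound 1 to compound 2 (within the scatter), which stayed within the scatter; compound 4 carries the same exchange with the methyl placed differently on the phenyl ring, so no step beyond the scatter is expected in this assay, in either direction. Compound 4 is therefore expected to give 6%, with a range of 0% to 15%, which corresponds to an expected step of a number 2.2 percentage points higher from compound 1 to compound 4 (within the scatter).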

Compound 4, percent growth inhibition at one concentration: 1.86%
Estimate against measurement, compound 4: 4.1 percentage points above; the range from low to high includes it.
By their numbers in this assay, from the lowest: compounds 4, 1, 2 and 3 (each within the scatter of the next, the first and the last beyond it).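

Among the compounds shown here, the methyl can be placed differently on the phenyl ring with little consequence here: in this assay there is a number 4.4 percentage points lower from compound 2 to compound 4 (within the scatter) for 3-methylphenyl in place of 4-methylphenyl, the first reading on methyl placement. The combined exchange gives a number 1.9 percentage points lower from compound 1 to compound 4 (within the scatter) and also stays within the scatter, so neither the identity of the substituent nor its place on the phenyl ring, as far as these changes go, separates compound 1, compound 2 and compound 4 at the single concentration tested. No measurement on hand speaks to why these steps are so small.

Open, on these data alone, is whether any group on this phenyl ring can move the number beyond the scatter, since compound 1, compound 2 and compound 4 differ only by one fluoro or methyl substituent, and an amine, a carboxylic acid or a longer alkyl chain in place of the methyl would test this. Also open is whether the similarity of these compounds would persist at other concentrations, which a single-concentration read-out cannot show.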